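Swapping the Aryl Group on a Piperazine Nitrogen

The compounds below may be only part of what the source reports. "The series", "measured", "known", "first", "only" and "open" are said of these compounds alone.

Three measured compounds share one core. In an assay on HEK293 cells for inhibition of Voltage-dependent T-type calcium channel subunit alpha-1G (Homo sapiens), read by fluorescence, tested at 10 uM (on this read-out lower numbers stand for less inhibition and higher numbers for more inhibition at the one concentration tested (going by the name of the read-out)), compound 1 `Cc1nc(-c2ccccc2)c(CNCCN2CCN(C(c3ccccc3)c3ccccc3)CC2)o1` gives 57.3%. Compound 3 `CCCc1nc(-c2ccccc2)c(CNCCN2CCN(C(c3ccccc3)c3ccccc3)CC2)o1` gives 71.9%, and the single-place step between them is a number 14.6 percentage points higher from compound 1 to compound 3 (beyond the scatter). Compound 2 `CCCc1nc(-c2ccccc2)c(CNCCCN2CCN(c3cccc(OC)c3)CC2)o1` gives 36.4%, the lowest of the three numbers: compound 1 stands above it beyond the scatter, and compound 3 further above still.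

Compound 4 `CCCc1nc(-c2ccccc2)c(CNCCCN2CCN(c3ccc(Cl)cc3)CC2)o1` differs from compound 2 in one place only: 4-chlorophenyl in place of 3-methoxyphenyl on an amine nitrogen in a ring. Among the measured compounds shown here, no measured step concerns such an exchange on the amine nitrogen in a ring. For the measured compounds named here, the only measured step, ethyl in place of hydrogen on a saturated chain carbon, touches a different part of the molecule, and compounds 1 and 3 differ from compound 2 in more than one place, so they give no direction for this change. The expectation is therefore a step within the scatter, a number 1.6 percentage points higher from compound 2 to compound 4 (within the scatter). The estimate for compound 4 in this assay is 38%, expected to fall between 22% and 58%.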

Compound 4, a percentage reported as inhibition, at one concentration (the size of the read-out at that concentration, not a potency): 63.3%
The estimate for compound 4 lay 25.3 percentage points below the measured number; measured number outside the range, above it.
By their numbers in this assay, from the lowest: compound 2; then compounds 1, 4 and 3 (each within the scatter of the next, the first and the last beyond it).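

In this assay, among the compounds shown here, the group on this amine nitrogen in a ring clearly affects the read-out, with the exchange giving a number 26.9 percentage points higher from compound 2 to compound 4 (beyond the scatter) in the first measured step at this position. The exchange changes both the substituent and its place on the phenyl ring, so this one step cannot show which of the two matters. Nothing available here explains the rise.

A 4-methoxyphenyl or 3-chlorophenyl group on the same nitrogen would separate the effect of the substituent from the effect of its place on the ring. A plain phenyl group there would show whether the chlorine raises the number, the methoxy lowers it, or both contribute.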